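The compounds below may be only part of what the source reports. "The series", "measured", "known", "first", "only" and "open" are said of these compounds alone.

Two members of the series with the shared core are on record. Compound 1 `O=S(=O)(NCCCNCc1ccc(Cl)c(C(F)(F)F)c1)c1cc(C(F)(F)F)cc(C(F)(F)F)c1` gives 8600 nM in a functional assay on BE(2)-C cells (Homo sapiens) for inhibition, read by MTT assay, with a stated time of 72 h; a lower number here means a stronger inhibitor of growth, a higher number a weaker inhibitor of growth. Compound 2 `CN(CCCNS(=O)(=O)c1cc(C(F)(F)F)cc(C(F)(F)F)c1)Cc1ccccc1` gives 28000 nM in this assay, the highest of the two numbers, with compound 1 the nearer one at a lower number beyond the scatter. Compound 3 `COc1ccc(CNCCCNS(=O)(=O)c2cc(C(F)(F)F)cc(C(F)(F)F)c2)cc1` has not been measured. It differs from compound 2 by (4-methoxybenzyl)amino in place of benzyl(methyl)amino on a saturated chain carbon, three bonds along the chain from a sulfonamide nitrogen. Since compound 1, which also carries a secondary amine on the chain, gives 8600 nM, a downward step of moderate size is expected from compound 2 to compound 3, a 2.3-fold lower number from compound 2 to compound 3 (0.37 log units; beyond the scatter). Compound 3 is therefore estimated at 12000 nM in this assay, within 5000 nM to 30000 nM.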

Compound 3, concentration for 50% growth inhibition: 2800 nM
Compound 3: the middle estimate sits 4.3-fold (0.63 log units) above what was measured; measured number below the stated range.
By their numbers in this assay, from the lowest: compound 3; then compound 1; then compound 2.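

In this assay, a step of a 10-fold lower number from compound 2 to compound 3 (1.00 log units; beyond the scatter) comes with (4-methoxybenzyl)amino in place of benzyl(methyl)amino on the saturated chain carbon. With the secondary amine common to both, a step of a 3.1-fold lower number from compound 1 to compound 3 (0.49 log units; beyond the scatter) comes with 4-methoxyphenyl in place of 4-chloro-3-(trifluoromethyl)phenyl, so the aryl group alone moves the number beyond the scatter. No measurement at hand accounts for either step. The first step joins two differences, the methyl group leaving and the methoxy group entering, and their shares remain unseparated. As far as these compounds go, whether a 4-fluorophenyl group or a longer chain would hold this level stays open.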